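Adding dimethylamino to compound 3: working notes

The source may report more compounds than this note shows. Statements on the series, on what has been measured and on what is new or still open speak of the compounds shown alone.

compound 1 `CC(=O)/C(C)=C/c1ccc(N(C)C)cc1` gives 150000 nM
compound 2 `C/C(=C\c1ccccc1)C(=O)/C=C/c1ccc([N+](=O)[O-])cc1` gives 43300 nM
compound 3 `COc1ccc(/C=C(\C)C(=O)/C=C/c2ccccc2)cc1` gives 44000 nM

In an ADME assay on LLC-MK2 cells (Macaca mulatta) for cytotoxicity, read by MTT assay, with a stated time of 48 h (on this read-out higher numbers stand for lower toxicity in this test and lower numbers for higher toxicity in this test), compound 3 gives 44000 nM and lies within the scatter of compound 2 at 43300 nM while compound 1 gives 150000 nM as a higher number, beyond the scatter of the other two.

For the measured compounds named here, compound 4 `COc1ccc(/C=C(\C)C(=O)/C=C/c2ccc(N(C)C)cc2)cc1` is compound 3 with dimethylamino in place of hydrogen on an aromatic carbon, para to a large group dimethylamino in place of hydrogen on an aromatic carbon and has no measurement yet. Going by the values given here, no measured pair isolates this change. Compound 1 also carries dimethylamino on an aromatic carbon and gives 150000 nM but it differs from compound 3 in other places too, so it offers only a weak hint of an upward move. In this assay the estimate is a 1.4-fold higher number from compound 3 to compound 4 (0.13 log units; within the scatter) and this expected step stays within the scatter. The expected value for compound 4 is 60000 nM with an estimated range from 20000 nM to 160000 nM as a working figure.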

Compound 4, half-maximal cytotoxic concentration: 411000 nM
Beside the measured number, compound 4's estimate is 6.9-fold (0.84 log units) below it; measured number above the stated range.
By their numbers in this assay, from the lowest: compounds 2 and 3 (each within the scatter of the next); then compound 1; then compound 4.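

In this assay, dimethylamino in place of hydrogen on an aromatic carbon, para to a large group, gives a 9.3-fold higher number from compound 3 to compound 4 (0.97 log units; beyond the scatter). For the compounds shown here, this is the first step that isolates this change, which the earlier compounds, differing in several places, could only hint at. It moves towards lower toxicity in this test, and nothing measured here accounts for its size.

From the compounds shown here alone, this is a single pair on a single core, so it remains open whether the same change gives a step of similar size in another setting. Going by these compounds, it is equally open whether the move is particular to dimethylamino or would also appear with a primary amine, a morpholine or a carboxylic acid at this place.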